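Compound 4 Against a Row of Assay Limits

A few compounds are considered here, and "the series" means these few. Any claim that something is new, unique, unknown or untested is made for them only; others in the source may bear on it.

Three compounds share one core and differ in a single group, on an aromatic carbon of a six-membered aromatic ring of carbon only, para to a large group. Compound 1 `CNC(=O)[C@@H](NC(=O)[C@@](O)(CCCN(Cc1ccc(Br)cc1)NC(=O)[C@@H](NC(=O)OC)C(C)(C)C)Cc1ccccc1)C(C)(C)C` carries bromo there, compound 2 `CNC(=O)[C@@H](NC(=O)[C@@](O)(CCCN(Cc1ccc(-c2cccnc2)cc1)NC(=O)[C@@H](NC(=O)OC)C(C)(C)C)Cc1ccccc1)C(C)(C)C` carries pyridin-3-yl and compound 3 `CNC(=O)[C@@H](NC(=O)[C@@](O)(CCCN(Cc1ccc(-c2ccsc2)cc1)NC(=O)[C@@H](NC(=O)OC)C(C)(C)C)Cc1ccccc1)C(C)(C)C` carries thiophen-3-yl. In an ADME assay on MT4 cells (Homo sapiens) for cytotoxicity, read by XTT assay, with a stated time of 5 days (a lower number here means that less compound is tolerated, a higher number that more compound is tolerated), compound 1 gives > 10000 nM, which is a limit. In this assay compound 2 gives > 50000 nM, also a limit. In this assay compound 3 gives > 50000 nM, again a limit, so it has no number of its own.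

Compound 4 `CNC(=O)[C@@H](NC(=O)[C@@](O)(CCCN(Cc1ccc(C#Cc2ccncc2)cc1)NC(=O)[C@@H](NC(=O)OC)C(C)(C)C)Cc1ccccc1)C(C)(C)C` has 2-(pyridin-4-yl)ethynyl in place of the thiophen-3-yl of compound 3: 2-(pyridin-4-yl)ethynyl in place of thiophen-3-yl on an aromatic carbon. Among the measured compounds shown here, three measured steps bear on this change, each an exchange of one group at the same place: a step that the two limits leave unreadable from compound 1 to compound 2, a step that the two limits leave unreadable from compound 1 to compound 3 and a step that the two limits leave unreadable from compound 2 to compound 3. None of them gives a size or a direction. Compound 4 is expected to stay close to compound 3, whose reading of > 50000 nM is a limit. No shift beyond the scatter is expected in either direction, and the estimated change is an at least 1.2-fold lower number from compound 3 to compound 4 (0.09 log units; that floor lies within the scatter). For compound 4 the estimate in this assay is 40000 nM, with an expected range from 12000 nM to 90000 nM.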

Compound 4, half-maximal cytotoxic concentration: > 50000 nM
Compound 4 gave a limit, no number; the forecaster's own chance of this, stated with the estimate: 75%; at least 1.2-fold (0.09 log units) between middle value and limit.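

In this assay compound 4 gives > 50000 nM, which is a limit. Among the compounds shown here, compound 1, compound 2 and compound 3 also stand only as limits, so no step to compound 4 from any of them can be read. The compounds shown leave open whether these four groups on the aromatic carbon differ in the concentration tolerated, and by how much.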